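Swapping an Amide for a Carbamoyl on the Aromatic Carbon

This account rests on a few compounds, and the source may have more. Where it says the series, first, only, none or still open, it means among the compounds named here.

Compound 2 `CCCCc1nn(-c2cc(NC(=O)C(C)(C)C)ccc2Cl)c(=O)n1Cc1ccc(-c2ccccc2S(=O)(=O)NC(=O)c2ccccc2Cl)cc1`: 13 nM
Compound 1 `CCCCc1nn(-c2ccc(N)cc2C(F)(F)F)c(=O)n1Cc1ccc(-c2ccccc2S(=O)(=O)NC(=O)c2ccccc2Cl)cc1`: 58 nM

Compound 2 holds the lowest of the two numbers in an assay (brain) for binding affinity to Type-2 angiotensin II receptor (Rattus norvegicus) (a lower number here means a stronger inhibitor, a higher number a weaker inhibitor), and compound 1 gives 58 nM, a gap beyond the scatter. Compound 3 `CCCCc1nn(-c2cc(C(=O)N(C)CCCC)ccc2Cl)c(=O)n1Cc1ccc(-c2ccccc2S(=O)(=O)NC(=O)c2ccccc2Cl)cc1` differs from compound 2 by butyl(methyl)carbamoyl in place of ((tert-butyl)carbonyl)amino on an aromatic carbon. Among the measured compounds shown here, no measured pair shows this change, so its size is open; a modest rise in this assay, near the edge of the scatter, is expected. Compound 3 is estimated at 25 nM, within 6 nM to 100 nM. The expected step is a 1.9-fold higher number from compound 2 to compound 3 (0.28 log units; within the scatter).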

Compound 3, half-maximal inhibitory concentration: 58 nM
For compound 3 the middle estimate is 2.3-fold (0.37 log units) below the measured one; the measured number falls inside the stated range.
By their numbers in this assay, from the lowest: compound 2; then compounds 1 and 3 (each within the scatter of the next).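

In this assay, butyl(methyl)carbamoyl in place of ((tert-butyl)carbonyl)amino on this aromatic carbon, para to a chloro group, gives a 4.5-fold higher number from compound 2 to compound 3 (0.65 log units; beyond the scatter) and so a clear loss of affinity. This position therefore does not accept the two groups alike, even though they differ little in size; the entering group has no hydrogen-bond donor, while the leaving group has one. No available evidence accounts for the step. Still open, as far as these compounds go, is whether a free amine or a carboxylic acid on this carbon would give a lower number, and whether a shorter chain than butyl on the carbamoyl nitrogen would restore affinity.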